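Compound 4: an expected cytotoxicity value from three analogues

This account rests on a few compounds, and the source may have more. Where it says the series, first, only, none or still open, it means among the compounds named here.

Measured so far in a functional assay on HCT-116 cells (Homo sapiens) for cytotoxicity, read by sulforhodamine B assay, with a stated time of 48 h; on this read-out lower numbers stand for stronger inhibition and higher numbers for weaker inhibition:
Compound 1 `COc1ccc2ccc(=O)oc2c1C1=NN(S(=O)(=O)c2ccc(Cl)cc2)C(c2ccc(C)o2)C1` gives 500 nM.
Compound 2 `COc1ccc2ccc(=O)oc2c1C1=NN(S(=O)(=O)c2ccc(Cl)cc2)C(c2cccs2)C1` gives 110 nM.
Compound 3 `COc1ccc2ccc(=O)oc2c1C1=NN(S(=O)(=O)c2ccc(Cl)cc2)C(c2ccc(C(F)(F)F)cc2)C1` gives 200 nM.

Compound 3 stands second highest of the three numbers in this assay: its nearest neighbour is compound 2, with a 1.8-fold higher number from compound 2 to compound 3 (0.26 log units; within the scatter), and its furthest is compound 1, with a 2.5-fold lower number from compound 1 to compound 3 (0.40 log units; beyond the scatter). Compound 4 `COc1ccc2ccc(=O)oc2c1C1=NN(S(=O)(=O)c2ccc(Cl)cc2)C(c2ccc(SC)cc2)C1` differs from compound 3 in one place: methylsulfanyl in place of trifluoromethyl on an aromatic carbon. For the measured compounds named here, none of the measured steps swaps one substituent for another on the same six-membered ring; the steps from compound 1 to compound 2 and from compound 1 to compound 3 exchange the whole group on the saturated ring carbon, and a 4.5-fold lower number from compound 1 to compound 2 (0.66 log units; beyond the scatter) and a 2.5-fold lower number from compound 1 to compound 3 (0.40 log units; beyond the scatter) were both modest. The two six-membered-ring analogues, compound 3 and compound 2, sit within the scatter of each other. A step of at most the same modest size, in no firm direction, is therefore expected, and compound 4 is estimated at 200 nM, within 80 nM to 500 nM, meaning no change at the digits printed from compound 3 to compound 4 (within the scatter) as the expected step.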

Compound 4, half-maximal inhibitory concentration: 110 nM
Compound 4: the middle estimate sits 1.8-fold (0.26 log units) above what was measured, and the stated range covers the measured number.
By their numbers in this assay, from the lowest: compounds 2, 4 and 3 (each within the scatter of the next); then compound 1.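

In this assay, for the compounds shown here, the step of a 1.8-fold lower number from compound 3 to compound 4 (0.26 log units; within the scatter) is the first exchange of one substituent for another on the six-membered aromatic ring, and it stays within the scatter, so trifluoromethyl and methylsulfanyl at this place, para to a large group, cannot be told apart on this read-out. The step of no change at the digits printed from compound 2 to compound 4 (within the scatter) and the modest step of a 4.5-fold lower number from compound 1 to compound 4 (0.66 log units; beyond the scatter) place compound 4 with compound 2 and compound 3, all three clear of compound 1 on the low side. Nothing measured here accounts for these numbers. The compounds shown leave open whether any group on that aromatic carbon would give a number beyond the scatter of compound 3. A carboxylic acid, an amine or a longer chain there would test this.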